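A few compounds are considered here, and "the series" means these few. Any claim that something is new, unique, unknown or untested is made for them only; others in the source may bear on it.

Measured so far in a functional assay on CHO-K1 cells for antagonist activity at transient receptor potential cation channel subfamily V member 1 (Homo sapiens), read by FLIPR; a lower number here means a stronger inhibitor, a higher number a weaker inhibitor:
compound 1 `CC(C(=O)NCc1ccc(C(F)(F)F)nc1)c1ccc(NS(C)(=O)=O)c(F)c1` gives "not active" (no number reported)
compound 2 `CC(C(=O)NCc1ccc(C(F)(F)F)nc1Nc1ccccc1)c1ccc(NS(C)(=O)=O)c(F)c1` gives 1400 nM
compound 3 `CC(C(=O)NCc1ccc(C(F)(F)F)nc1N1CCCC1)c1ccc(NS(C)(=O)=O)c(F)c1` gives 211 nM

Among the compounds with values here, compound 3 has the lowest number of the two that were reported; the nearest is compound 2, and the only step that bears on the present question is a 6.6-fold lower number from compound 2 to compound 3 (0.82 log units; beyond the scatter), a modest gain. Compound 4 `CC(C(=O)NCc1ccc(C(F)(F)F)nc1N1CCCCCCC1)c1ccc(NS(C)(=O)=O)c(F)c1` differs from compound 3 in one place: a group of 8 heavy atoms (7 carbon, 1 nitrogen; one eight-membered non-aromatic ring with 1 hetero atom) in place of a group of 5 heavy atoms (4 carbon, 1 nitrogen; one five-membered non-aromatic ring with 1 hetero atom), on an aromatic carbon. Within the data shown here, no measured pair tells how the size of such a saturated ring on that aromatic carbon matters, so the expectation rests on compound 3 alone. Compound 4 is therefore estimated at 300 nM, with a range of 80 nM to 1200 nM; this means an expected step of a 1.4-fold higher number from compound 3 to compound 4 (0.15 log units; within the scatter), which lies within the scatter.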

Compound 4, half-maximal inhibitory concentration: 27.8 nM
The estimate for compound 4 lay 11-fold (1.03 log units) above the measured number, outside the stated range (below it).
By their numbers in this assay, from the lowest: compound 4; then compound 3; then compound 2.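

In this assay, the position next to the ring nitrogen proves sensitive to the size of the saturated ring, with a 7.6-fold lower number from compound 3 to compound 4 (0.88 log units; beyond the scatter) when the eight-membered ring replaces pyrrolidin-1-yl. Set against the anilino group, the same ring gives a 50-fold lower number from compound 2 to compound 4 (1.70 log units; beyond the scatter), the widest gap among the compounds with numbers. No measurement at hand accounts for this gain. The compounds shown leave open whether the number falls steadily through piperidin-1-yl and azepan-1-yl, and whether morpholin-4-yl or an open-chain dialkylamino group would fit the same picture.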